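Side-chain replacements on the sulfanylmethyl arm of the shared core

A few compounds are considered here, and "the series" means these few. Any claim that something is new, unique, unknown or untested is made for them only; others in the source may bear on it.

Measured compounds:
compound 1, `N#Cc1c(N)nc(SCc2cccnc2)c(C#N)c1-c1ccc(OCC2CC2)cc1`: 67 nM
compound 2, `N#Cc1c(N)nc(SCc2cccc(C(N)=O)c2)c(C#N)c1-c1ccc(OCC2CC2)cc1`: 83 nM
compound 3, `N#Cc1c(N)nc(SCC(=O)NO)c(C#N)c1-c1ccc(OCC2CC2)cc1`: 536 nM

All three numbers come from an assay on CHO cells for displacement of a labelled ligand from adenosine receptor A1 (Homo sapiens), read by scintillation counting, with a stated time of 90 min; a lower number here means a stronger inhibitor, a higher number a weaker inhibitor. Within this set compound 3 stands highest, separated from compound 2 by a step beyond the scatter and from compound 1 by a slightly larger one. Compound 1 and compound 2 sit within the scatter of each other, as a 1.2-fold higher number from compound 1 to compound 2 (0.09 log units; within the scatter) shows.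

The next compound, compound 4 `N#Cc1c(N)nc(SCc2ncn[nH]2)c(C#N)c1-c1ccc(OCC2CC2)cc1`, differs from compound 3 in one place: 1H-1,2,4-triazol-5-yl in place of hydroxycarbamoyl on a saturated chain carbon bound to a sulfur.

Among the measured compounds shown here, the steps that bear on this change are an 8.0-fold higher number from compound 1 to compound 3 (0.90 log units; beyond the scatter) and a 6.5-fold higher number from compound 2 to compound 3 (0.81 log units; beyond the scatter). Both run from an aromatic ring on that chain carbon to hydroxycarbamoyl and both raise the number by a modest amount. Compound 4 runs the other way, back to an aromatic ring, now a five-membered one with three hetero atoms. The step is therefore expected to go downward and beyond the scatter in this assay, a 4.1-fold lower number from compound 3 to compound 4 (0.62 log units; beyond the scatter), though not necessarily all the way back to compound 1. Compound 4 is estimated at 130 nM, with a range from 50 nM to 400 nM.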

Compound 4, inhibition constant: 338 nM
Compound 4: the middle estimate sits 2.6-fold (0.41 log units) below what was measured, and the stated range covers the measured number.
By their numbers in this assay, from the lowest: compounds 1 and 2 (each within the scatter of the next); then compounds 4 and 3 (each within the scatter of the next).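

In this assay, an aromatic ring on a saturated chain carbon bound to a sulfur is not enough on its own to hold the number near those of compound 1 and compound 2: a 1.6-fold lower number from compound 3 to compound 4 (0.20 log units; within the scatter) leaves 1H-1,2,4-triazol-5-yl and hydroxycarbamoyl indistinguishable here. The steps of a 4.1-fold higher number from compound 2 to compound 4 (0.61 log units; beyond the scatter) and a 5.0-fold higher number from compound 1 to compound 4 (0.70 log units; beyond the scatter) place this five-membered ring apart from both six-membered aromatic groups, so the earlier contrast between aromatic rings and hydroxycarbamoyl does not extend to compound 4. Nothing available explains this difference among the aromatic rings.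

Still open, from the compounds shown here alone, is whether a five-membered aromatic ring with fewer hetero atoms, such as imidazolyl or thienyl, would group with compound 1 and compound 2 or with compound 3 and compound 4. A carboxylic acid on the same chain carbon, or a longer chain carrying 1H-1,2,4-triazol-5-yl, would also remain to be placed.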